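This account rests on a few compounds, and the source may have more. Where it says the series, first, only, none or still open, it means among the compounds named here.

Measured compounds in a physicochemical assay for solubility, in the presence of a further agent that is not named here; on this read-out higher numbers stand for higher solubility and lower numbers for lower solubility:

compound 1, `Cc1ccc2c(c1)[n+]([O-])c(N)n[n+]2[O-]`: 3000000 nM
compound 2, `CCCN(CCC)CCNc1n[n+]([O-])c2ccccc2[n+]1[O-]`: > 25000000 nM (a limit, not a number)
compound 3, `[O-][n+]1nc(NCCN2CCCCC2)[n+]([O-])c2cc(Cl)ccc21`: 3200000 nM

Three compounds built on the same core have been run in this assay . Compound 1 gives 3000000 nM. Compound 3 gives 3200000 nM, a number that lies within the usual scatter of the number for compound 1, so the two cannot be told apart. Going by the values given here, for compound 2 the assay reports only a limit, > 25000000 nM, and no number; this is the one value that sits at the limit of > 25000000 nM in this assay, at which 1 of the 3 values shown sits.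

Compound 4, `Cc1ccc2c(c1)[n+]([O-])c(NCCN(C)C)n[n+]2[O-]`, is not yet measured. It differs from compound 1 in one place: 2-(dimethylamino)ethyl in place of hydrogen on a nitrogen on an aromatic ring. Among the compounds with values here, no pair of the measured compounds differs in a single place, so there is no measured step of the same kind to lean on. Among the measured compounds, compound 2 is the only one whose value sits at the limit rather than at a number.

For compound 4 an upward step in this assay is expected, beyond the scatter, as a 2.7-fold higher number from compound 1 to compound 4 (0.43 log units; beyond the scatter) shows. The expected value for compound 4 is 8000000 nM, within a range from 2500000 nM to 25000000 nM.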

Compound 4, solubility: > 51000000 nM
Compound 4 was reported as a limit; the forecaster's own chance of this, stated with the estimate: 25%; middle value at least 6.3-fold (0.80 log units) from the limit.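

In this assay, going by these compounds alone, the swap of hydrogen for 2-(dimethylamino)ethyl on this nitrogen gives an at least 17-fold higher number from compound 1 to compound 4 (1.23 log units; beyond the scatter) as the first single change on the shared core that can be read on its own. It shows that this one place can move the read-out well beyond the scatter. Going by these compounds, compound 4 is reported as a limit and not as a number, so the step gives only a floor and its full size stays unknown: the limit of > 51000000 nM in this assay, at which 1 of the 4 values shown sits.

The compounds shown do not separate the effect of the chain from that of its dimethylamino end. On these data alone, it also remains open whether a longer chain, a chain ending in a hydroxyl group or a carboxylic acid on this nitrogen would shift the read-out in the same direction.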